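Methoxy to hydroxy on a shared pyrazole-bearing core

This account rests on a few compounds, and the source may have more. Where it says the series, first, only, none or still open, it means among the compounds named here.

Measured compounds:
compound 1 `COc1cc(C)cc(-c2nn(CC#N)cc2-c2ccc(-c3cccc(C(C)=O)c3)nc2)c1` — 97%
compound 2 `Cc1cc(O)cc(-c2nn(CC#N)cc2-c2ccnc(-c3ccc(Oc4ccccc4)cc3)c2)c1` — 88%
compound 3 `COc1cc(C)cc(-c2nn(CC#N)cc2-c2ccnc(-c3ccc(N(C)C)cc3)c2)c1` — 88%

In a functional assay on Malme-3M cells (Homo sapiens) for cytotoxicity, read by sulforhodamine B assay, with a stated time of 48 h, tested at 0.001 uM (a lower number here means a stronger effect, a higher number a weaker effect of the compound at the concentration tested), compound 3 gives 88%, which at the digits shown is level with compound 2 and sits with it at the low end of the three numbers. Compound 1 gives 97%, and its gap to compound 3 stays within the scatter, so no order among the three can be read from these values.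

Compound 4 `Cc1cc(O)cc(-c2nn(CC#N)cc2-c2ccnc(-c3ccc(N(C)C)cc3)c2)c1` differs from compound 3 in one place: hydrogen in place of methyl on an oxygen on an aromatic ring. Among the measured compounds shown here, no pair of measured compounds differs by this single change, so nothing is known here of its effect on its own. What can be said is that compound 2, which carries the hydroxy in the same position alongside a different group on the other ring, sits at 88%, close to compound 3.

On that basis the step from compound 3 to compound 4 is expected to be no change at the digits printed from compound 3 to compound 4 (within the scatter), none beyond the scatter. Compound 4 is therefore estimated at 88%, within 75% to 100%.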

Compound 4, a percentage reported as activity, at one concentration (the size of the read-out at that concentration, not a potency): 91%
Compound 4: the middle estimate sits 3 percentage points below what was measured; the range from low to high includes it.
By their numbers in this assay, from the lowest: compounds 2, 3, 4 and 1 (each within the scatter of the next).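

In this assay the change from methoxy to hydroxy on the 3-methoxy-5-methylphenyl group now has a measured step of its own, a number 3 percentage points higher from compound 3 to compound 4 (within the scatter) at this single concentration, so this replacement of methyl by hydrogen on the oxygen does not separate the pair. With the hydroxy kept in place, dimethylamino in place of phenoxy on an aromatic carbon gives a number 3 percentage points higher from compound 2 to compound 4 (within the scatter) and so does not separate that pair either. Nothing measured here offers an explanation for these values.

The compounds shown leave open whether an ethoxy group or a longer chain on that oxygen, or an amine or a carboxylic acid in its place, would move the number beyond the scatter. From the compounds shown here alone, it also remains open whether methoxy to hydroxy would read the same on compound 1 or at a higher concentration.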